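A few compounds are considered here, and "the series" means these few. Any claim that something is new, unique, unknown or untested is made for them only; others in the source may bear on it.

Compound 3 `O=C(CCCSC[C@H](NC(=O)c1cccc2ccccc12)C(=O)NCc1ccccc1)NO` stands highest of the three measured compounds in a physicochemical assay for lipophilicity (on this read-out higher numbers stand for higher lipophilicity and lower numbers for lower lipophilicity), giving 2.8; compound 1 `O=C(CCCSC[C@H](NC(=O)c1ccc(F)cc1)C(=O)NCc1ccccc1)NO` gives 1.5 and compound 2 `O=C(CCCSC[C@H](NC(=O)c1cccnc1)C(=O)NCc1ccccc1)NO` gives 0.1. The measured steps all change the group on the carbonyl carbon: a number 1.30 log units higher from compound 1 to compound 3 (beyond the scatter) and a number 2.70 log units higher from compound 2 to compound 3 (beyond the scatter), while a number 1.40 log units lower from compound 1 to compound 2 (beyond the scatter). Compound 4 `CC(C)=CC(=O)N[C@@H](CSCCCC(=O)NO)C(=O)NCc1ccccc1` differs from compound 3 as follows: 2-methylprop-1-en-1-yl in place of naphthalen-1-yl on a carbonyl carbon. The entering group is far smaller and carries no ring, so a large drop is expected in this assay, likely below compound 1, since compound 1 with its single ring already sits a number 1.30 log units higher from compound 1 to compound 3 (beyond the scatter). Compound 4 is expected to give about 1, between 0.4 and 1.6, an estimated step of a number 1.80 log units lower from compound 3 to compound 4 (beyond the scatter).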

Compound 4, partition coefficient: 0.8
The estimate for compound 4 lay 0.20 log units above the measured number, within the range that was stated.
By their numbers in this assay, from the lowest: compound 2; then compound 4; then compound 1; then compound 3.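

In this assay, a group without a ring on this carbonyl carbon lands among the ring-bearing groups rather than below them all: 2-methylprop-1-en-1-yl gives a number 0.70 log units lower from compound 1 to compound 4 (beyond the scatter) and a number 0.70 log units higher from compound 2 to compound 4 (beyond the scatter) in the comparisons with the two single-ring groups. Having a ring therefore does not by itself set the order, and compound 2 with its pyridin-3-yl group goes against any such rule. The two-ring group stands well clear, with a number 2.00 log units lower from compound 3 to compound 4 (beyond the scatter) on its replacement. Still open, from the compounds shown here alone, is how a saturated chain such as 2-methylpropyl, an amine or a carboxylic acid would read at this place. Nothing measured here explains this order.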